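The source may hold more compounds than are shown below. What is called first, only, known or untested is meant among the compounds shown, and "the series" means these compounds.

Values in a functional assay on A549 cells (Homo sapiens) for inhibition; a lower number here means a stronger inhibitor, a higher number a weaker inhibitor:

- compound 1 `COCCOc1cc(/C=C/c2ccc3ccccc3c2)ccc1OC`: 2990 nM
- compound 2 `COCCOc1cc(/C=C\c2ccc3ccccc3c2)ccc1OC`: 2990 nM
- compound 3 `CN(C)c1ccc(/C=C/c2ccc3ccccc3c2)cc1`: 3660 nM

Compound 2 gives 2990 nM, level with compound 1, and compound 3 at 3660 nM lies within the usual scatter of that pair. So the three numbers form one tight group.

The next compound to be tested is compound 4 `COc1ccc(/C=C\c2ccc3ccccc3c2)cc1N`. Here amino takes the place of 2-methoxyethoxy on an aromatic carbon, ortho to a methoxy group: amino in place of 2-methoxyethoxy on an aromatic carbon.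

Among the compounds with values here, only one measured step exists, no change at the digits printed from compound 1 to compound 2 (within the scatter), and it reflects (the fact that compounds 1 and 2 differ only in the configuration as drawn). That step leaves the 2-methoxyethoxy group untouched, so it shows that flipping the double bond made no visible difference but gives no measure of swapping this group. With no direct guide, the tight grouping of the three values is the main anchor, and only a small move is expected. The expected change is a 1.7-fold lower number from compound 2 to compound 4 (0.22 log units; within the scatter), an estimate that carries real uncertainty in either direction. For compound 4 the estimated value is 1800 nM, with an expected range of 200 nM to 6000 nM.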

Compound 4, half-maximal inhibitory concentration: > 20000 nM
Compound 4 was reported as a limit (the forecaster's own chance of this, stated with the estimate: 8%); middle value at least 11-fold (1.04 log units) from the limit.
By their numbers in this assay, from the lowest: compounds 1, 2 and 3 (each within the scatter of the next). At a limit, above all of these: compound 4.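

In this assay compound 4 reads > 20000 nM, which is a limit of the assay and not a number. Putting amino in place of 2-methoxyethoxy on this aromatic carbon, ortho to a methoxy group, gives an at least 6.6-fold higher number from compound 2 to compound 4 (0.82 log units; beyond the scatter), the first step shown that lies beyond the scatter, so what sits at this position clearly matters in a way the earlier compounds could not reveal. This step gives only a minimum size, and its true size remains unknown: the limit of > 20000 nM in this assay, at which 1 of the 4 values shown sits.

The swap removes a five-heavy-atom chain and brings in a hydrogen-bond donor in one move, and the compounds shown do not separate these two changes. A hydroxyl or a short ethoxy group on the same carbon could help tell whether the weaker inhibition follows the loss of the chain or the arrival of the amino.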